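Swapping the aryl group on the best of three compounds

The source may hold more compounds than are shown below. What is called first, only, known or untested is meant among the compounds shown, and "the series" means these compounds.

Values in a functional assay on MCF-A cells (Homo sapiens) for cytotoxicity; on this read-out lower numbers stand for stronger inhibition of growth and higher numbers for weaker inhibition of growth:
- Compound 1 `COc1ccc(C2=C(c3ccc(SC)cc3)CC3CCCN3C2=O)cc1O`: 5000 nM
- Compound 2 `COc1ccc(C2=C(c3ccc(SC)cc3)CC3CCCN3C2=O)cc1Br`: 6000 nM
- Compound 3 `COc1ccc(C2=C(c3ccc(SC)cc3)CC3CCCN3C2=O)cc1C`: 400 nM

Of these three, compound 3 has the lowest number, and its steps to both others lie beyond the scatter. Compound 4 `CSc1ccc(C2=C(c3ccc(F)c(F)c3)C(=O)N3CCCC3C2)cc1` has not yet been measured. It differs from compound 3 by 3,4-difluorophenyl in place of 4-methoxy-3-methylphenyl on a double-bonded ring carbon.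

The measured steps all change one group on this same aromatic ring. Methyl in place of hydroxy gave a 13-fold lower number from compound 1 to compound 3 (1.10 log units; beyond the scatter), and methyl in place of bromo gave a 15-fold lower number from compound 2 to compound 3 (1.18 log units; beyond the scatter). Bromo in place of hydroxy gave only a 1.2-fold higher number from compound 1 to compound 2 (0.08 log units; within the scatter). Within the data shown here, compound 4 has no methyl on this ring, and no measured compound carries fluorine, so these steps are only a loose guide. With them as that guide, a large rise toward the values of compound 1 and compound 2 is expected in this assay.

The expected change is a 6.3-fold higher number from compound 3 to compound 4 (0.80 log units; beyond the scatter).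

The estimate for compound 4 is 2500 nM, with an expected range of 500 nM to 10000 nM.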

Compound 4, concentration for 50% growth inhibition: 800 nM
For compound 4 the middle estimate is 3.1-fold (0.49 log units) above the measured one, and the stated range covers the measured number.
By their numbers in this assay, from the lowest: compounds 3 and 4 (each within the scatter of the next); then compounds 1 and 2 (each within the scatter of the next).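

In this assay, the whole aryl group on this double-bonded ring carbon can be exchanged with a step that stays within the scatter (a 2.0-fold higher number from compound 3 to compound 4 (0.30 log units; within the scatter)). Among these compounds, the earlier compounds changed only one group on the ring, and there methyl alone stood apart, but compound 4 has neither that methyl nor the methoxy group. Compound 4 still stands apart from the hydroxy and bromo compounds (a 6.3-fold lower number from compound 1 to compound 4 (0.80 log units; beyond the scatter); a 7.5-fold lower number from compound 2 to compound 4 (0.88 log units; beyond the scatter)), so among these four compounds a low number does not depend on the 4-methoxy-3-methylphenyl group.

On these data alone, it remains open whether both fluorines are needed, and how a phenyl group carrying an amine, a nitrile or a carboxylic acid would behave here. Nothing given here offers a measured explanation for these differences.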